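The compounds below may be only part of what the source reports. "The series", "measured", "known", "first", "only" and "open" are said of these compounds alone.

Working notes on the series. Compound 1 `O=C1C(Nc2ccc(Br)cc2)=CC(=O)c2c1nc1n2[C@H]2OC[C@@H](O)[C@H]2OC1` gives 4330 nM in a functional assay on MCF7 cells (Homo sapiens) for inhibition, read by sulforhodamine B assay (a higher number here means a weaker inhibitor, a lower number a stronger inhibitor), the higher of the two numbers recorded there. Compound 2 `CCOc1ccc(NC2=CC(=O)c3nc4n(c3C2=O)[C@H]2OC[C@@H](O)[C@H]2OC4)cc1` gives 1430 nM in this assay, a lower number and beyond the scatter. For compound 3 `O=C1C=C(Nc2ccccc2)C(=O)c2c1nc1n2[C@H]2OC[C@@H](O)[C@H]2OC1` this assay reports only a limit, > 4000 nM. For the measured compounds named here, the one measured single-point step is an at least 2.7-fold higher number from compound 2 to compound 3 (0.44 log units; beyond the scatter), so removing the ethoxy on the aromatic carbon of compound 2 gives a weaker inhibitor, its full size bounded by the limit of > 4000 nM in this assay, at which 1 of the 3 values shown sits.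

Compound 4 `CCOc1ccccc1NC1=CC(=O)c2c(nc3n2[C@H]2OC[C@@H](O)[C@H]2OC3)C1=O` differs from compound 1 by 2-ethoxyphenyl in place of 4-bromophenyl on an amine nitrogen. The ethoxy step bears on this change only in part: there ethoxy gave way to hydrogen, here 2-ethoxyphenyl takes the place of 4-bromophenyl, and the substitution pattern of the 2-ethoxyphenyl ring is not that of compound 2. What can be said is that the ethoxy-bearing compound 2 sits at 1430 nM while the bromine-bearing compound 1 sits at 4330 nM. A modest move toward a lower number is therefore expected for compound 4, though it may stay within the scatter. The expected step is a 1.7-fold lower number from compound 1 to compound 4 (0.24 log units; within the scatter). Compound 4 is estimated at 2500 nM in this assay, within a range from 1000 nM to 6000 nM.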

Compound 4, half-maximal inhibitory concentration: > 4000 nM
Compound 4: a limit, no number; the forecaster's own chance of this, stated with the estimate: 30%; middle value at least 1.6-fold (0.20 log units) away from the limit.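

In this assay, for the compounds shown here, compound 4 gives only a limit of > 4000 nM and no number, so no step from compound 1 to compound 4 can be read: the limit of > 4000 nM in this assay, at which 2 of the 4 values shown sit. The compounds shown leave open whether 2-ethoxyphenyl in place of 4-bromophenyl on the amine nitrogen gives a stronger or a weaker inhibitor, and by how much.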